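Chloro to iodo on the pyridine core of compound 2

The source may hold more compounds than are shown below. What is called first, only, known or untested is meant among the compounds shown, and "the series" means these compounds.

The two measured compounds share one core and differ only in the ring carried on the side chain. Compound 1 `Clc1ncc(OC[C@@H]2CCCN2)cc1-c1cccnc1` in an assay on membranes from brain with Neuronal acetylcholine receptor; alpha4/beta2 (Rattus norvegicus) as the target (a higher number here means a weaker inhibitor, a lower number a stronger inhibitor), gives 0.021 nM, while compound 2 `Clc1ncc(OC[C@@H]2CCN2)cc1-c1cccnc1` in this assay gives 0.0081 nM. The step of a 2.6-fold lower number from compound 1 to compound 2 (0.41 log units; beyond the scatter) is the only one measured. Compound 2 therefore stands with the lowest of the two numbers, with compound 1 as its nearest neighbour.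

Compound 3 `Ic1ncc(OC[C@@H]2CCN2)cc1-c1cccnc1` keeps the side chain of compound 2 and changes the halogen on the core: iodo in place of chloro on an aromatic carbon. Going by the values given here, no measured step here concerns a change of halogen; the single recorded step from compound 1 to compound 2 dealt with the saturated ring on the chain and says nothing about this position. The expectation for compound 3 in this assay therefore rests on compound 2 alone, and a step of a 1.2-fold higher number from compound 2 to compound 3 (0.09 log units; within the scatter), that is, no change beyond the usual scatter, is expected. For compound 3 an estimate of 0.01 nM is given, expected to fall between 0.003 nM and 0.035 nM.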

Compound 3, inhibition constant: 0.0117 nM
Compound 3: middle estimate off by 1.2-fold (0.07 log units), on the low side; measured number inside the range.
By their numbers in this assay, from the lowest: compounds 2, 3 and 1 (each within the scatter of the next, the first and the last beyond it).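

In this assay, iodo in place of chloro on the aromatic carbon next to the ring nitrogen, ortho to a pyridin-3-yl group and para to a (azetidin-2-yl)methoxy group, gives a 1.4-fold higher number from compound 2 to compound 3 (0.16 log units; within the scatter). Going by these compounds alone, the only earlier step concerned the saturated ring on the side chain, so this is the first reading at this position on the core: with the azetidin-2-yl side chain kept, the assay does not separate chloro from iodo here. Nothing available explains this result or bears on it.

As far as these compounds go, the two halogens cover only a narrow part of what this position could carry, so it remains open what a hydrogen, a methyl group, an amine or a nitrile would give here, and whether any such group would produce a step beyond the scatter. From the compounds shown here alone, it is also open whether iodo and chloro would remain indistinguishable on the pyrrolidin-2-yl side chain of compound 1, since the present comparison rests on the azetidin-2-yl side chain alone.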